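Isobutyl for Phenyl on the Amide of a Shared Core

The compounds below may be only part of what the source reports. "The series", "measured", "known", "first", "only" and "open" are said of these compounds alone.

The measured compounds and their values:
compound 1, `CCCSc1nc(Cl)c2c(n1)N(Cc1ccccc1)C(C(=O)Nc1ccccc1)N2`: 58400 nM
compound 2, `CCCSc1nc(Cl)c2c(n1)N(Cc1ccco1)C(C(=O)N1CCN(C)CC1)N2`: 53800 nM
compound 3, `CCCSc1nc(Cl)c2c(n1)N(CC1CCCCC1)C(C(=O)N1CCN(C)CC1)N2`: > 64000 nM, a limit of the assay

In a functional assay on MGC-803 cells (Homo sapiens) for antiproliferative activity, read by MTT assay, with a stated time of 72 h (on this read-out higher numbers stand for weaker inhibition and lower numbers for stronger inhibition), compound 1 gives 58400 nM, the highest of the two numbers obtained, with compound 2 nearest at 53800 nM; the two sit within the usual scatter of each other, so no order between them can be read. For compound 3 the assay reports only a limit, > 64000 nM. Among the compounds with values here, the one step between measured compounds, an at least 1.1-fold higher number from compound 2 to compound 3 (0.07 log units; that floor lies within the scatter), puts cyclohexyl in place of furan-2-yl on a saturated chain carbon bound to a nitrogen on an aromatic ring in a ring, and its floor rests on (the limit of > 64000 nM in this assay, at which 1 of the 3 values shown sits).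

Compound 4, `CCCSc1nc(Cl)c2c(n1)N(Cc1ccccc1)C(C(=O)NCC(C)C)N2`, differs from compound 1 by isobutyl in place of phenyl on an amide-type nitrogen. Within the data shown here, no measured step touches the amide-type nitrogen, and the single step that exists changes another part of the core and ends at a limit. The data therefore give no ground to expect a step beyond the scatter in either direction in this assay.

Compound 4 is estimated at 58000 nM, in the range from 25000 nM to 130000 nM. That estimate means an expected step of a 1.0-fold lower number from compound 1 to compound 4 (0.00 log units; within the scatter).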

Compound 4, half-maximal inhibitory concentration: 58400 nM
Compound 4: middle estimate off by 1.0-fold (0.00 log units), on the low side; measured number inside the range.
By their numbers in this assay, from the lowest: compounds 2, 1 and 4 (each within the scatter of the next). At a limit, above all of these: compound 3.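

In this assay, within the data shown here, the first reading at this position comes from putting isobutyl in place of phenyl on the amide-type nitrogen, with no change at the digits printed from compound 1 to compound 4 (within the scatter) as the result. This shows that, on this core and in this range of numbers, an open chain of carbon can stand where a six-membered aromatic ring stood without any change that can be told from the scatter of the assay, even though the entering group has fewer heavy atoms and no ring. The data shown give no measured property that would explain why the number stays where it is.

Isobutyl and phenyl both consist of carbon only and count no hydrogen-bond donors or acceptors, so it stays open whether an amine, a carboxylic acid or a longer chain on this nitrogen would move the number beyond the scatter. As far as these compounds go, since this one pair shares a single core, it also stays open whether the same exchange would read alike with a different group elsewhere on that core.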